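The source may report more compounds than this note shows. Statements on the series, on what has been measured and on what is new or still open speak of the compounds shown alone.

Three compounds share one core and differ only in the aryl group carried on the amide nitrogen. Compound 1 `COc1cc2c(cc1OC)C(CC(=O)Nc1cccc(Cl)c1)CC2` gives 31.3% in a functional assay on the whole organism (strain Wistar) for inhibition, with Rattus norvegicus as the target, read by paw edema, with a stated time of 1 h, at a dose of 100 mg/kg; a lower number here means less inhibition, a higher number more inhibition at the dose given (going by the name of the read-out). Compound 2 `COc1cc2c(cc1OC)C(CC(=O)Nc1ccc(Cl)cc1)CC2` gives 71.9% in this assay, and compound 3 `COc1cc2c(cc1OC)C(CC(=O)Nc1ccc(Br)cc1)CC2` gives 50%. Among these three numbers compound 3 stands second highest: the step of a number 18.7 percentage points higher from compound 1 to compound 3 (beyond the scatter) lies beyond the scatter, as does the step of a number 21.9 percentage points lower from compound 2 to compound 3 (beyond the scatter), so compound 3 sits between the other two. The largest step is a number 40.6 percentage points higher from compound 1 to compound 2 (beyond the scatter).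

Compound 4 `COc1cc2c(cc1OC)C(CC(=O)Nc1ccccc1C)CC2` has not yet been measured in this assay. It differs from compound 3 in one place: 2-methylphenyl in place of 4-bromophenyl on an amide-type nitrogen. Within the data shown here, none of the measured steps places a 2-methylphenyl on the amide nitrogen, so no step matches this change directly. What the three measured steps do show is that the group on the phenyl ring moves the read-out by modest to large amounts, in both directions. Among the measured compounds shown here, with no direct precedent, the expectation for compound 4 is set near the middle of the measured spread with a wide range, which means an expected step of a number 8 percentage points lower from compound 3 to compound 4 (within the scatter). The estimate for compound 4 in this assay is therefore 42%, with a range from 15% to 68%.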

Compound 4, a percentage reported as inhibition, in the whole organism at one dose (the size of the read-out at that dose, not a potency): 21.9%
Compound 4: the middle estimate sits 20.1 percentage points above what was measured; measured number inside the range.
By their numbers in this assay, from the lowest: compounds 4 and 1 (each within the scatter of the next); then compound 3; then compound 2.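

Among these compounds, replacing the halogen-bearing ring with 2-methylphenyl is the first change in which the group on the phenyl ring is not a halogen, and in this assay it gives a number 28.1 percentage points lower from compound 3 to compound 4 (beyond the scatter) and a number 50 percentage points lower from compound 2 to compound 4 (beyond the scatter) as clear drops from the two compounds with a 4-substituted ring. Against the remaining halogen compound the picture differs: a number 9.4 percentage points lower from compound 1 to compound 4 (within the scatter) means that 2-methylphenyl and 3-chlorophenyl cannot be told apart here. Across these four compounds, then, the 4-chlorophenyl and 4-bromophenyl groups both read higher than the other two, and the new compound extends that split to a ring with no halogen, though two halogens and one methyl group make a very small set.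

The compounds shown leave open whether the fall follows the methyl group itself or the place it holds on the ring, as group and place change together in this step. A plain phenyl ring, or an amine or a carboxylic acid on the ring, would also remain to be placed on this scale. Nothing given here accounts for the differences between these aryl groups.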